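Swapping One Butyl Group for Another on an Amine Nitrogen

A few compounds are considered here, and "the series" means these few. Any claim that something is new, unique, unknown or untested is made for them only; others in the source may bear on it.

Measured compounds:
- compound 1, `COc1cc(/C=C/C(=O)/C=C(/C=C/c2ccc(OC(C)=O)c(OC)c2)NC2CCCCC2)ccc1OC(C)=O`: 62%
- compound 2, `CC(C)CNC(=C\C(=O)/C=C/c1ccc(O)cc1)/C=C/c1ccc(O)cc1`: 82%
- compound 3, `COc1cc(/C=C/C(=O)/C=C(/C=C/c2ccc(OC(C)=O)c(OC)c2)NCC(C)C)ccc1OC(C)=O`: 77%

In a functional assay on Caco-2 cells (Homo sapiens), read by fluorescence, tested at 10 uM (a lower number here means a stronger effect, a higher number a weaker effect of the compound at the concentration tested), compound 3 gives 77%, the second highest of the three numbers. Compound 2 gives 82%, which lies within the usual scatter of the value of compound 3, so the two cannot be told apart. Going by the values given here, compound 1 stands further off: the one measured step at the amine nitrogen, a number 15 percentage points higher from compound 1 to compound 3 (beyond the scatter), shows a modest rise when a ring gave way to a chain.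

Compound 4, `CCC(C)NC(=C\C(=O)/C=C/c1ccc(OC(C)=O)c(OC)c1)/C=C/c1ccc(OC(C)=O)c(OC)c1`, differs from compound 3 by sec-butyl in place of isobutyl on an amine nitrogen. Among the compounds with values here, only the step from compound 1 to compound 3 bears on this place, and it involved a change from a ring to a chain, a larger alteration than the present one, where a four-carbon chain is replaced by another four-carbon chain with no change in donors, acceptors or charge. Compound 4 is therefore expected to show no step beyond the scatter, no change at the digits printed from compound 3 to compound 4 (within the scatter). The estimated value for compound 4 is 77%, with a range from 65% to 89%.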

Compound 4, a percentage reported as activity, at one concentration (the size of the read-out at that concentration, not a potency): 86%
Compound 4: the middle estimate sits 9 percentage points below what was measured, and the stated range covers the measured number.
By their numbers in this assay, from the lowest: compound 1; then compounds 3, 2 and 4 (each within the scatter of the next).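

In this assay, sec-butyl in place of isobutyl on the amine nitrogen gives a number 9 percentage points higher from compound 3 to compound 4 (within the scatter) and so leaves these two four-carbon chains indistinguishable at this position. Sec-butyl in place of cyclohexyl gives a number 24 percentage points higher from compound 1 to compound 4 (beyond the scatter) and thereby adds a second chain that reads higher than the cyclohexyl ring of compound 1, where the earlier compounds offered only isobutyl for that comparison. The data offer no measured explanation for the separation between the ring and the two chains.

Going by these compounds, whether this separation belongs to cyclohexyl alone remains open, and a cyclopentyl or a phenyl group on the same nitrogen would test that. A methyl group or a longer chain such as n-hexyl could show whether other chains fall with isobutyl and sec-butyl.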